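The source may hold more compounds than are shown below. What is called first, only, known or untested is meant among the compounds shown, and "the series" means these compounds.

Of the compounds shown here, three sharing one core have been measured in a functional assay on BJAB cells (Homo sapiens) for antiproliferative activity, with a stated time of 4 days; on this read-out lower numbers stand for an effect already at smaller amounts and higher numbers for an effect only at larger amounts of compound. Compound 1 `Cc1ccc(-c2c(C)nn(-c3nc(-c4ccc(Cl)c(Cl)c4)c(SC(C)C)s3)c2C(=O)O)cc1` gives 3800 nM. Compound 2 `CNc1cc(-c2c(C)nn(-c3nc(-c4ccc(Cl)c(Cl)c4)c(SC(C)C)s3)c2C(=O)O)ccn1` gives 18000 nM, and compound 3 `Cc1nn(-c2nc(-c3ccc(Cl)c(Cl)c3)c(SC(C)C)s2)c(C(=O)O)c1-c1cccnc1` gives 12000 nM. Among these three numbers compound 3 holds the second highest place. Its value sits close to that of compound 2, as a 1.5-fold lower number from compound 2 to compound 3 (0.18 log units; within the scatter), while compound 1 lies further off, as a 3.2-fold higher number from compound 1 to compound 3 (0.50 log units; beyond the scatter).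

Compound 4 `CC(=O)Nc1ccc(-c2c(C)nn(-c3nc(-c4ccc(Cl)c(Cl)c4)c(SC(C)C)s3)c2C(=O)O)cc1` differs from compound 3 in one place: 4-acetamidophenyl in place of pyridin-3-yl on an aromatic carbon.

Among the measured compounds shown here, two measured steps bear on this change. Exchanging the carbon-only six-membered ring of compound 1 for a six-membered ring holding one nitrogen raised the number, as a 3.2-fold higher number from compound 1 to compound 3 (0.50 log units; beyond the scatter), and a related exchange gave a 4.7-fold higher number from compound 1 to compound 2 (0.68 log units; beyond the scatter). For the measured compounds named here, compound 4 returns to a carbon-only ring, as in compound 1, yet the 4-acetamidophenyl group differs from the 4-methylphenyl group of compound 1, and no measured pair shows what that difference does here. A fall in the number for compound 4, toward the value of compound 1, is therefore expected, though a modest one. The expected step is a 2.4-fold lower number from compound 3 to compound 4 (0.38 log units; beyond the scatter). The estimate for compound 4 in this assay is 5000 nM, with a range from 1500 nM to 16000 nM.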

Compound 4, half-maximal effective concentration: 139000 nM
Compound 4: middle estimate off by 28-fold (1.44 log units), on the low side, outside the stated range (above it).
By their numbers in this assay, from the lowest: compound 1; then compounds 3 and 2 (each within the scatter of the next); then compound 4.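

In this assay, the aromatic carbon next to the ring atom that bears a carboxy group proves more sensitive to the group placed on it than the first three compounds suggested, as 4-acetamidophenyl gives a 12-fold higher number from compound 3 to compound 4 (1.06 log units; beyond the scatter) and a 7.7-fold higher number from compound 2 to compound 4 (0.89 log units; beyond the scatter). The clearest comparison is with compound 1, where acetamido in place of methyl on the same carbon-only ring gives a 37-fold higher number from compound 1 to compound 4 (1.56 log units; beyond the scatter), a larger step than the exchange of ring type in a 3.2-fold higher number from compound 1 to compound 3 (0.50 log units; beyond the scatter), so a carbon-only ring alone does not keep the number low and the group carried on that ring matters greatly. Nothing available here accounts for the size of this step.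

With only methyl and acetamido shown on the carbon-only ring, it remains open which part of acetamido goes with the higher number, the amide hydrogen or the carbonyl, and whether a methoxy or a hydroxyl group in its place would give a number nearer that of compound 1. As far as these compounds go, it is also open whether acetamido would give a similar step on a six-membered ring holding one nitrogen.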